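The compounds below may be only part of what the source reports. "The series", "measured", "known", "first", "only" and "open" are said of these compounds alone.

In a functional assay on DU-145 cells (Homo sapiens) for inhibition, read by trypan blue exclusion, with a stated time of 96 h (a lower number here means a stronger inhibitor of growth, a higher number a weaker inhibitor of growth), compound 1 `Nc1c(Br)cc(Br)cc1/C=C(\C(=O)c1ccc(Br)cc1)S(=O)(=O)c1ccc(Br)cc1` gives 25000 nM, the higher of the two numbers recorded so far. Compound 3 `Cc1ccc(CS/C(=C/c2ccc(Br)cc2)C(=O)c2ccc(Cl)cc2)cc1` gives 10000 nM in this assay, a lower number than compound 1 by a step beyond the usual scatter. Compound 2 `O=C(/C(=C\c1ccc(Br)cc1)S(=O)(=O)c1ccc(Br)cc1)c1ccccc1O` gives no number in this assay, only a limit, > 100000 nM. Compound 4 `O=C(/C(=C\c1ccc(Br)c(O)c1)S(=O)(=O)c1ccc(Br)cc1)c1ccc(Br)cc1` has not yet been measured in this assay. It differs from compound 1 in one place: 4-bromo-3-hydroxyphenyl in place of 2-amino-3,5-dibromophenyl on a double-bonded chain carbon bound to a double-bonded chain carbon. Going by the values given here, no measured pair shows this kind of exchange, so the size of the step is open; a step no larger than the scatter, in either direction, is what is expected, as in a 1.2-fold higher number from compound 1 to compound 4 (0.08 log units; within the scatter). Compound 4 is therefore expected to give about 30000 nM in this assay, within a range from 8000 nM to 100000 nM.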

Compound 4, concentration for 50% growth inhibition: 50000 nM
The estimate for compound 4 lay 1.7-fold (0.22 log units) below the measured number, within the range that was stated.
By their numbers in this assay, from the lowest: compound 3; then compounds 1 and 4 (each within the scatter of the next). At a limit, above all of these: compound 2.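

Placing 4-bromo-3-hydroxyphenyl in place of 2-amino-3,5-dibromophenyl on a double-bonded chain carbon bound to a double-bonded chain carbon gives a 2.0-fold higher number from compound 1 to compound 4 (0.30 log units; within the scatter) in this assay. At this place, then, one substituted aromatic ring can replace another, with different substituents, without a change that can be read in this assay. No measurement shown bears on why the step stays this small.

Both groups contain a six-membered aromatic ring of carbon only. As far as these compounds go, what a group without such a ring would give at this place, such as a carboxylic acid or a longer chain, remains open.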